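Larger Alkyl Group on the Aromatic Ring: Cytotoxicity Outlook

This account rests on a few compounds, and the source may have more. Where it says the series, first, only, none or still open, it means among the compounds named here.

Compound 2 `Cc1ccc(OCCCCCn2ccc(=O)[nH]c2=O)cc1` carries a methyl group on its aromatic ring. In an ADME assay on HEL cells (Homo sapiens) for cytotoxicity (on this read-out lower numbers stand for higher toxicity in this test and higher numbers for lower toxicity in this test), compound 2 gives > 100000 nM, which is a limit of the test rather than a measured number. Compound 1 `O=c1ccn(CCCCCOc2ccccc2)c(=O)[nH]1` lacks that methyl. In this assay compound 1 gives > 100000 nM, again a limit. The pair therefore yields a step that the two limits leave unreadable from compound 1 to compound 2, and the two values sit together at the limit of > 100000 nM in this assay, at which 2 of the 2 values shown sit. Compound 3 `CC(C)c1ccc(OCCCCCn2ccc(=O)[nH]c2=O)cc1` differs from compound 2 by isopropyl in place of methyl on an aromatic carbon. Among the measured compounds shown here, no readable measured step bears on this change, and the single step available gives no size. The expected step of a number no higher from compound 2 to compound 3 (the limit leaves the size open) is therefore no change beyond the scatter. For compound 3 the estimate in this assay is 100000 nM, within a range from 30000 nM to 300000 nM, with a strong chance that the test once more reports only a limit rather than a number.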

Compound 3, half-maximal cytotoxic concentration: > 100000 nM
Compound 3 was reported as a limit; the forecaster's own chance of this, stated with the estimate: 75%; the middle value lies on the limit itself.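

The steps among compound 1, compound 2 and compound 3 cannot be read, as all three values in this assay are limits: the limit of > 100000 nM in this assay, at which 3 of the 3 values shown sit. As far as these compounds go, how far the true values lie from that limit, and whether methyl or isopropyl shifts them, stays open.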